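This account rests on a few compounds, and the source may have more. Where it says the series, first, only, none or still open, it means among the compounds named here.

Compound 1 `CCCCCCOc1cccc(O)c1C(=O)/C=C/c1ccc(O)cc1`: > 30000 nM
Compound 2 `CC(C)(C)CCOc1cccc(O)c1C(=O)/C=C/c1ccc(O)cc1`: 3220 nM

In a functional assay on PC-3 cells (Homo sapiens) for antiproliferative activity, read by sulforhodamine B assay (on this read-out lower numbers stand for stronger inhibition of growth and higher numbers for weaker inhibition of growth), compound 1 stands at the limit of > 30000 nM in this assay, at which 1 of the 2 values shown sits. This is a limit and not a number.

Compound 3 `CC(C)CCOc1cccc(O)c1C(=O)/C=C/c1ccc(O)cc1` has not yet been measured. It differs from compound 1 by isopropyl in place of butyl on a saturated chain carbon, two bonds along the chain from an oxygen on an aromatic ring. The change lies on a saturated chain carbon, two bonds along the chain from an oxygen on an aromatic ring.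

Among the measured compounds shown here, one measured step bears on this change: an at least 9.3-fold lower number from compound 1 to compound 2 (0.96 log units; beyond the scatter). There, tert-butyl takes the place of the same butyl. From that step to compound 2, a lower number is also expected for compound 3, though probably a smaller drop, and another limit remains possible. The expected change is an at least 3.7-fold lower number from compound 1 to compound 3 (0.57 log units; beyond the scatter). For compound 3 the estimate is 8000 nM, with an expected range of 2500 nM to 30000 nM.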

Compound 3, concentration for 50% growth inhibition: 11500 nM
Compound 3: the middle estimate sits 1.4-fold (0.16 log units) below what was measured; the measured number falls inside the stated range.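

In this assay, the lower number is no longer tied to the tert-butyl end of compound 2. Isopropyl also gives one: an at least 2.6-fold lower number from compound 1 to compound 3 (0.41 log units; beyond the scatter). The two branched ends are not equivalent, however: a 3.6-fold higher number from compound 2 to compound 3 (0.55 log units; beyond the scatter), so hydrogen in place of one methyl at this chain carbon gives a change beyond the scatter. From the compounds shown here alone, the true size of the step from the unbranched hexyl chain remains unknown, since compound 1 stands at a limit and not at a number: the limit of > 30000 nM in this assay, at which 1 of the 3 values shown sits.

These three compounds leave open whether another end, such as cyclohexyl or phenyl, would bring the number lower than in compound 2. They also leave open how an amine or a carboxylic acid at the end of this chain would read out.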